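Lengthening a Hydroxyalkyl Side Chain in a Cyclic Peptide

The compounds below may be only part of what the source reports. "The series", "measured", "known", "first", "only" and "open" are said of these compounds alone.

Compound 1 `COc1ccc(C[C@H]2C(=O)N[C@@H](C)C(=O)N(C)[C@H]3Cc4ccc(cc4)Oc4cc(ccc4OC)C[C@@H](C(=O)N[C@H](C)C(=O)N[C@@H](CO)C(=O)N2C)N(C)C3=O)cc1`, compound 2 `COc1ccc(C[C@H]2C(=O)N[C@@H](C)C(=O)N(C)[C@H]3Cc4ccc(cc4)Oc4cc(ccc4OC)C[C@@H](C(=O)N[C@H](C)C(=O)N[C@@H](CCCO)C(=O)N2C)N(C)C3=O)cc1` and compound 3 `C=CC[C@@H]1NC(=O)[C@@H](C)NC(=O)[C@@H]2Cc3ccc(OC)c(c3)Oc3ccc(cc3)C[C@@H](C(=O)N2C)N(C)C(=O)[C@H](C)NC(=O)[C@H](Cc2ccc(OC)cc2)N(C)C1=O` share one core and differ only in a single side chain. In a functional assay on P388 cells (Mus musculus) for cytotoxicity (on this read-out higher numbers stand for weaker inhibition and lower numbers for stronger inhibition), compound 1 gives 14.1 nM, compound 2 gives 174 nM and compound 3 gives 38.9 nM, so compound 3 stands second highest of the three, nearer to compound 1 than to compound 2. Compound 4 `COc1ccc(C[C@H]2C(=O)N[C@@H](C)C(=O)N(C)[C@H]3Cc4ccc(cc4)Oc4cc(ccc4OC)C[C@@H](C(=O)N[C@H](C)C(=O)N[C@@H](CCCCO)C(=O)N2C)N(C)C3=O)cc1` carries 3-hydroxypropyl in place of vinyl on a saturated chain carbon bound to a saturated ring carbon. For the measured compounds named here, two measured steps bear on this: a 12-fold higher number from compound 1 to compound 2 (1.09 log units; beyond the scatter) and a 4.5-fold lower number from compound 2 to compound 3 (0.65 log units; beyond the scatter). Going from hydroxy to 2-hydroxyethyl weakened inhibition markedly, and vinyl in place of 2-hydroxyethyl recovered part of it. A still longer hydroxyalkyl chain is therefore expected to weaken inhibition again, a 7.7-fold higher number from compound 3 to compound 4 (0.89 log units; beyond the scatter). Compound 4 is estimated at 300 nM, within 100 nM to 1000 nM.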

Compound 4, half-maximal inhibitory concentration: 219 nM
The estimate for compound 4 lay 1.4-fold (0.14 log units) above the measured number, and the stated range covers the measured number.
By their numbers in this assay, from the lowest: compound 1; then compound 3; then compounds 2 and 4 (each within the scatter of the next).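

In this assay the two longest hydroxyalkyl chains cannot be told apart: a 1.3-fold higher number from compound 2 to compound 4 (0.10 log units; within the scatter) stays within the scatter, so the steep loss seen on the first lengthening does not simply continue. The weakening holds up against both other side chains, with a 5.6-fold higher number from compound 3 to compound 4 (0.75 log units; beyond the scatter) and a 16-fold higher number from compound 1 to compound 4 (1.19 log units; beyond the scatter) marking the full distance from the shortest chain. Nothing available accounts for this flat stretch. As far as these compounds go, whether a still longer chain would stay level, or an amine or carboxylic acid at the chain end would read differently from the hydroxy, remains open.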